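A few compounds are considered here, and "the series" means these few. Any claim that something is new, unique, unknown or untested is made for them only; others in the source may bear on it.

Measured so far in an assay on isolated protein for binding affinity to 5-hydroxytryptamine receptor 6 (Homo sapiens); a lower number here means a stronger inhibitor, a higher number a weaker inhibitor:
compound 1 `COc1ccc(-c2n[nH]cc2N2CCNCC2)cc1`, 279 nM;
compound 2 `Clc1ccc(-c2n[nH]cc2N2CCNCC2)cc1`, 75 nM;
compound 3 `Fc1ccc(-c2n[nH]cc2N2CCNCC2)cc1`, 373 nM.

Compound 3 carries the highest number of the three. Its gap to compound 1 is within the scatter, a 1.3-fold higher number from compound 1 to compound 3 (0.13 log units; within the scatter), whereas the step of a 5.0-fold higher number from compound 2 to compound 3 (0.70 log units; beyond the scatter) lies beyond it, so only compound 2 is clearly set apart.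

Compound 4 `Cc1ccc(-c2n[nH]cc2N2CCNCC2)cc1` differs from compound 3 by methyl in place of fluoro on an aromatic carbon. Going by the values given here, no measured compound carries methyl at this carbon, so the expectation rests on the exchanges already seen there: fluoro and methoxy give numbers within the scatter of each other, chloro gives the only clearly lower one. A modest move toward a lower number in this assay is therefore expected, with a wide range. The expected step is a 2.2-fold lower number from compound 3 to compound 4 (0.34 log units; beyond the scatter). For compound 4 the estimate in this assay is 170 nM, between 60 nM and 450 nM.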

Compound 4, inhibition constant: 653 nM
The estimate for compound 4 lay 3.8-fold (0.58 log units) below the measured number; measured number outside the range, above it.
By their numbers in this assay, from the lowest: compound 2; then compounds 1, 3 and 4 (each within the scatter of the next, the first and the last beyond it).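

In this assay, methyl at this aromatic carbon does not follow chloro, as an 8.7-fold higher number from compound 2 to compound 4 (0.94 log units; beyond the scatter) shows, while a 1.8-fold higher number from compound 3 to compound 4 (0.24 log units; within the scatter) leaves methyl and fluoro unseparated. Methyl does separate from methoxy, with a 2.3-fold higher number from compound 1 to compound 4 (0.37 log units; beyond the scatter), although compound 3 lies within the scatter of both, so compound 2 alone stands clearly apart from every other compound. No available evidence bears on why chloro and methyl differ here.

From the compounds shown here alone, whether bromo or a nitrile at this carbon would track compound 2 stays open. So does whether chloro keeps its number at another carbon of this ring.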